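The source may hold more compounds than are shown below. What is called first, only, known or untested is meant among the compounds shown, and "the series" means these compounds.

Measured so far in a functional assay for agonist activity at Glucose-dependent insulinotropic receptor (Homo sapiens); a higher number here means that more compound is needed for the effect, a lower number that less compound is needed:
compound 1 `CS(=O)(=O)c1ccc(Nc2ncnc(N3CCC(c4nc(C5CC5)no4)CC3)c2[N+](=O)[O-])cc1`: 25 nM
compound 2 `CCS(=O)(=O)c1ccc(Nc2ncnc(N3CCC(c4nc(C(C)C)no4)CC3)c2[N+](=O)[O-])cc1`: 17 nM

Compound 2 has the lower of the two numbers, yet its gap to compound 1 lies within the scatter, so the two read as equal in this assay. Compound 3 `CCSc1ccc(Nc2ncnc(N3CCC(c4nc(C(C)C)no4)CC3)c2[N+](=O)[O-])cc1` has not been measured. It differs from compound 2 by ethylsulfanyl in place of ethylsulfonyl on an aromatic carbon. Within the data shown here, no step of this kind has been measured, so the expectation rests on the change alone. A moderate rise in the number is expected, beyond the scatter: a 4.1-fold higher number from compound 2 to compound 3 (0.61 log units; beyond the scatter). Compound 3 is accordingly estimated at 70 nM, with a range of 20 nM to 250 nM.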

Compound 3, half-maximal effective concentration: 110 nM
For compound 3 the middle estimate is 1.6-fold (0.20 log units) below the measured one; measured number inside the range.
By their numbers in this assay, from the lowest: compounds 2 and 1 (each within the scatter of the next); then compound 3.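

In this assay the change from 4-(ethylsulfonyl)phenyl to 4-(ethylsulfanyl)phenyl gives a 6.5-fold higher number from compound 2 to compound 3 (0.81 log units; beyond the scatter) with the rest of the structure held constant. Among these compounds, this is the first single-place step, and it shows that the group on this aromatic carbon affects the number, with ethylsulfonyl giving the lower value of the pair. Nothing at hand explains the step.

Open, on these data alone, is whether a sulfonamide, a carboxylic acid or an amine at this place would match ethylsulfonyl. Also open, as far as these compounds go, is whether the same step would appear on the core of compound 1.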